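Stretching hydroxymethyl to 2-hydroxyethyl

The compounds below may be only part of what the source reports. "The series", "measured", "known", "first", "only" and "open" are said of these compounds alone.

In an ADME assay on MT2 cells (Homo sapiens) for cytotoxicity, read by XTT assay, with a stated time of 4 days (a lower number here means that less compound is tolerated, a higher number that more compound is tolerated), compound 3 (`Cc1nc(C(NC(=O)C(=O)Nc2ccc(F)cc2F)C2CCCCN2)sc1CO`) gives > 110000 nM and this is a limit, not a number. Compound 1 (`Cc1ccc(NC(=O)C(=O)NC(c2nc(C)c(CCO)s2)C2CCCCN2)c(F)c1`) also gives only a limit, > 78800 nM in this assay. Compound 2 (`Cc1nc(C(NC(=O)C(=O)Nc2ccc(Cl)c(F)c2)C2CCCCN2)sc1CCO`) gives the limit > 41000 nM in the same test. Compound 4 (`Cc1nc(C(NC(=O)C(=O)Nc2ccc(F)cc2F)C2CCCCN2)sc1CCO`) differs from compound 3 by a single change (hydroxymethyl in place of hydroxy on a saturated chain carbon bound to an aromatic carbon) that turns hydroxymethyl into 2-hydroxyethyl. Among the measured compounds shown here, the only measured step (a step that the two limits leave unreadable from compound 1 to compound 2) swaps a different group and cannot be sized, so it offers no guide. Compound 1 and compound 2 already carry 2-hydroxyethyl, and neither gives more than a limit. No step beyond the scatter is expected in this assay (an at least 1.1-fold lower number from compound 3 to compound 4 (0.04 log units; that floor lies within the scatter)). For compound 4 the estimate is 100000 nM (expected range 40000 nM to 200000 nM).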

Compound 4, half-maximal cytotoxic concentration: > 105000 nM
Compound 4 gave a limit, no number; the forecaster's own chance of this, stated with the estimate: 85%; middle value at least 1.0-fold (0.02 log units) from the limit.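

Among the compounds shown here, compound 4 gives only a limit, as do compound 1, compound 2 and compound 3, so no step among them can be read. The compounds shown leave open each one's actual cytotoxic concentration, and whether hydroxymethyl to 2-hydroxyethyl changes it.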